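The compounds below may be only part of what the source reports. "The series", "measured", "known", "first", "only" and "open" are said of these compounds alone.

Compound 2 `Cc1nc(-c2ccccc2)c(C(=O)N2CCN(c3cccc(C)c3C)CC2)o1` carries a 2,3-dimethylphenyl group on the ring nitrogen of its piperazine-like ring, joined through an amide to the shared core. In a functional assay on HL-60 cells (Homo sapiens) for inhibition, read by MTT assay, with a stated time of 72 h (on this read-out higher numbers stand for weaker inhibition and lower numbers for stronger inhibition), compound 2 gives 35 nM. Compound 3 `COc1cc(OC)cc(N2CCN(C(=O)c3onc(C)c3-c3ccccc3)CC2)c1` shares the general layout but differs in its core and in the group on the amine nitrogen; in this assay compound 3 gives 152 nM. Among the two numbers known, compound 2 stands lowest, and the gap to compound 3 lies beyond the usual scatter. Compound 1 `COc1ccc(-c2nc(C)oc2C(=O)N2CCN(c3cccc(Cl)c3)CC2)cc1OC`, with a different core and a 3-chlorophenyl group, is reported in this assay as "not active" (no number reported), with no number given.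

Compound 4 `Cc1nc(-c2ccccc2)c(C(=O)N2CCN(c3ccc(Cl)c(Cl)c3)CC2)o1` is not yet measured. It keeps the core of compound 2 and changes only the group on the amine nitrogen: 3,4-dichlorophenyl in place of 2,3-dimethylphenyl on an amine nitrogen in a ring. Within the data shown here, no measured pair shows this exact exchange, so the expectation rests on the spread already seen. A step in the direction of weaker inhibition is expected from compound 2 to compound 4, of a size near the edge of the scatter, as a 2.3-fold higher number from compound 2 to compound 4 (0.36 log units; beyond the scatter). Compound 4 is estimated to give 80 nM in this assay, within a range from 20 nM to 320 nM.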

Compound 4, half-maximal inhibitory concentration: 124 nM
Beside the measured number, compound 4's estimate is 1.6-fold (0.19 log units) below it; the range from low to high includes it.
By their numbers in this assay, from the lowest: compound 2; then compounds 4 and 3 (each within the scatter of the next).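

Among these compounds, this is the first direct comparison on the shared core at this amine nitrogen: in this assay, exchanging 2,3-dimethylphenyl for 3,4-dichlorophenyl gives a 3.5-fold higher number from compound 2 to compound 4 (0.55 log units; beyond the scatter). The two groups have the same number of heavy atoms, and neither has hydrogen-bond donors or acceptors, so these counts do not separate them, yet the numbers do differ. Compound 4 also remains clearly measurable, so this position tolerates the change with only a modest loss. No measurement available here accounts for the difference between these two groups.

The pair changes both the kind of substituent and where it sits on the phenyl ring, so the contribution of each remains unresolved. As far as these compounds go, how a plain phenyl group or a cyclohexyl ring would behave at this nitrogen on the same core also remains open.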